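A few compounds are considered here, and "the series" means these few. Any claim that something is new, unique, unknown or untested is made for them only; others in the source may bear on it.

Measured in a functional assay on U-87MG ATCC cells for antiproliferative activity against U-87 MG (Homo sapiens), read by spectrophotometry, with a stated time of 2 days; on this read-out higher numbers stand for weaker inhibition of growth and lower numbers for stronger inhibition of growth:

- Compound 1 `Cc1ccc(Nc2ncc(C(F)(F)F)c(N3Cc4cccc(N(C)S(C)(=O)=O)c4C3)n2)cc1C`: > 30000 nM (a limit)
- Compound 2 `COc1ccc(C(F)(F)F)cc1Nc1ncc(C(F)(F)F)c(N2Cc3cccc(N(C)S(C)(=O)=O)c3C2)n1`: > 30000 nM (a limit)
- Compound 3 `CN(c1cccc2c1CN(c1nc(Nc3cccc(Oc4ccccc4)c3)ncc1C(F)(F)F)C2)S(C)(=O)=O`: 19500 nM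

Compound 1 has only a limit, > 30000 nM, and not a number. Among the compounds with values here, compound 3 is the one compound here with a number, 19500 nM.

The next compound to be tested is compound 4 `Cc1cc(Cl)ccc1Nc1ncc(C(F)(F)F)c(N2Cc3cccc(N(C)S(C)(=O)=O)c3C2)n1`, which has 4-chloro-2-methylphenyl in place of 3,4-dimethylphenyl on a nitrogen on an aromatic ring.

One measured step changes the same place: a step that the two limits leave unreadable from compound 1 to compound 2. It therefore gives no size to carry over. Within the data shown here, compound 1 and compound 2 share (the limit of > 30000 nM in this assay, at which 2 of the 3 values shown sit), so the only guide is that this group of compounds tends to sit at that limit, with compound 3 going against it. No step beyond the scatter is expected in this assay, in either direction. The expected step is a number no higher from compound 1 to compound 4 (the limit leaves the size open). Compound 4 is estimated at 30000 nM, with an expected range from 15000 nM to 60000 nM.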

Compound 4, concentration for 50% growth inhibition: 28300 nM
The estimate for compound 4 lay 1.1-fold (0.03 log units) above the measured number; low and high end bracket the measured number.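

In this assay, 4-chloro-2-methylphenyl on a nitrogen on an aromatic ring gives compound 4 a measured number, where 3,4-dimethylphenyl and 2-methoxy-5-(trifluoromethyl)phenyl gave only a limit; the change reads as an at least 1.0-fold lower number from compound 1 to compound 4 (0.02 log units; that floor lies within the scatter) and as an at least 1.0-fold lower number from compound 2 to compound 4 (0.02 log units; that floor lies within the scatter). Among these three compounds, changing the group at this place has therefore shown no step beyond the scatter, and the true size of both steps stays open. Compound 4 does not join the two compounds held at the limit: the limit of > 30000 nM in this assay, at which 2 of the 4 values shown sit.

The compounds shown leave open whether the chlorine or the methyl of compound 4 matters more for the number. They also leave open whether a phenyl carrying a morpholine or a carboxylic acid at this place would move the number beyond the scatter.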